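The source may report more compounds than this note shows. Statements on the series, on what has been measured and on what is new or still open speak of the compounds shown alone.

Within the data shown here, in a functional assay on HT-29 cells (Homo sapiens) for inhibition, read by MTT assay, with a stated time of 120 h (on this read-out higher numbers stand for weaker inhibition and lower numbers for stronger inhibition), compound 2 `CC(NC(=O)C#Cc1ccc(NC(=O)Nc2cc(C(F)(F)F)ccc2Cl)cc1)c1ccccc1` gives 3170 nM, and this stands as the only number in the set. Compound 1 `C/C(=C\c1ccc(NC(=O)Nc2ccc(Cl)c(C(F)(F)F)c2)cc1)C(=O)NC(C)c1ccccc1` sits at a limit of this assay, reported as > 50000 nM, which is a limit and not a number (the limit of > 50000 nM in this assay, at which 1 of the 2 values shown sits). Compound 3 `CC(NC(=O)C#Cc1ccc(NC(=O)Nc2ccc(Cl)c(C(F)(F)F)c2)cc1)c1ccccc1` has not yet been measured; it differs from compound 2 by 4-chloro-3-(trifluoromethyl)phenyl in place of 2-chloro-5-(trifluoromethyl)phenyl on an amide-type nitrogen. Among the measured compounds shown here, compound 1 carries the same 4-chloro-3-(trifluoromethyl)phenyl group as compound 3, yet it differs from compound 2 in a second place as well, so no single step links the two measured values; the pair shows only one number and one limit. Compound 3 is therefore expected to move toward weaker inhibition by a modest step, a 1.9-fold higher number from compound 2 to compound 3 (0.28 log units; within the scatter), with real uncertainty. Compound 3 is estimated at 6000 nM, within 1200 nM to 30000 nM.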

Compound 3, half-maximal inhibitory concentration: 4920 nM
Compound 3: the middle estimate sits 1.2-fold (0.09 log units) above what was measured; the range from low to high includes it.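

In this assay, 4-chloro-3-(trifluoromethyl)phenyl in place of 2-chloro-5-(trifluoromethyl)phenyl on an amide-type nitrogen gives a 1.6-fold higher number from compound 2 to compound 3 (0.19 log units; within the scatter), so these two groups, made of the same atoms, are not told apart on this read-out. Compound 3 also gives the 4-chloro-3-(trifluoromethyl)phenyl group its first real number in the set, since until now it stood only in compound 1, whose result is a limit. Nothing measured here accounts for how the two groups compare.

Open, on these data alone, is whether a group of another kind on this nitrogen, such as a phenyl ring carrying a carboxylic acid or an amine, would leave the read-out where it stands. The step between compound 3 and compound 1 cannot be read, because the result for compound 1 is a limit and not a number.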